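Stability outlook for compound 4 after tert-butoxy replaces tert-butyl

This account rests on a few compounds, and the source may have more. Where it says the series, first, only, none or still open, it means among the compounds named here.

The series shares one core: compound 1 is `C[C@@H](O)[C@H]1C(=O)N2C(C(=O)OCOC(=O)C(C)(C)C)=C(S[C@@H]3CN[C@H](C(=O)Nc4cccc(C(=O)O)c4)C3)[C@H](C)[C@H]12`, compound 2 is `C[C@@H](O)[C@H]1C(=O)N2C(C(=O)OCOC(=O)C(C)(C)C)=C(S[C@@H]3CN[C@H](C(=O)Nc4cccc(C(=O)OCOC(=O)C(C)(C)C)c4)C3)[C@H](C)[C@H]12` and compound 3 is `COC(=O)OCOC(=O)C1=C(S[C@@H]2CN[C@H](C(=O)Nc3cccc(C(=O)OCOC(=O)OC)c3)C2)[C@H](C)[C@@H]2[C@@H]([C@@H](C)O)C(=O)N12`. In an ADME assay for metabolic stability, read by LC-MS, with a stated time of 3 h, at pH 6.5, tested at 50 uM (on this read-out higher numbers stand for a more stable compound and lower numbers for a less stable compound), compound 1 gives > 95%, which is a limit of the assay rather than a number. Compound 2 reaches > 95%, again only a limit. Compound 3 stands at > 95%, also a limit. Among the measured compounds shown here, the single step measured within one place, a step that the two limits leave unreadable from compound 1 to compound 2, cannot be sized because of the limit of > 95% in this assay, at which 3 of the 3 values shown sit, so no step in this assay has yet yielded a readable size. Compound 4 is `C[C@@H](O)[C@H]1C(=O)N2C(C(=O)OCOC(=O)OC(C)(C)C)=C(S[C@@H]3CN[C@H](C(=O)Nc4cccc(C(=O)O)c4)C3)[C@H](C)[C@H]12`. It differs from compound 1 in one place: tert-butoxy in place of tert-butyl on a carbonyl carbon. For the measured compounds named here, no measured step covers this change, and the one step that touches the same ester is itself hidden by the limit, so nothing measured argues for a loss of stability. Compound 4 is therefore expected to sit at the same limit, with an expected step that the limit leaves unreadable from compound 1 to compound 4. For compound 4 the estimate is 96%, in the range 88% to 100%.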

Compound 4, percent of the compound remaining: > 95%
Compound 4: no number, only a limit; the forecaster's own chance of this, stated with the estimate: 80%; the middle value is on the limit's open side.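

In this assay compound 4 gives > 95% as a limit and not a number. No size can be read for the step from compound 1 to compound 4 because both values are limits: the limit of > 95% in this assay, at which 4 of the 4 values shown sit. The compounds shown leave open whether tert-butoxy in place of tert-butyl on a carbonyl carbon shifts stability at all.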